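The source may hold more compounds than are shown below. What is called first, only, known or untested is meant among the compounds shown, and "the series" means these compounds.

Working notes on the series. Compound 3, `O=C(/C(=C\c1c[nH]c2ccccc12)SCc1ccc(F)cc1)c1ccc(Cl)cc1`, stands lowest of the three numbers in a functional assay on DU-145 cells (Homo sapiens) for inhibition, read by trypan blue exclusion, with a stated time of 96 h (a lower number here means a stronger inhibitor of growth, a higher number a weaker inhibitor of growth), giving 1000 nM. Compound 2, `COc1ccccc1/C=C(/SCc1ccc(F)cc1)C(=O)c1ccc(Cl)cc1`, gives 10000 nM, and compound 1, `CN(C)c1ccc(/C=C(/SCc2ccc(Cl)cc2Cl)C(=O)c2ccc(Cl)cc2)cc1`, gives 50000 nM. For the measured compounds named here, the one step recorded within the measured set runs a 10-fold lower number from compound 2 to compound 3 (1.00 log units; beyond the scatter); it is the only measured change on this position, and it shows that the group at this position can shift the read-out by a modest amount beyond the scatter.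

Compound 4, `CN(C)c1ccc(/C=C(/SCc2ccc(F)cc2)C(=O)c2ccc(Cl)cc2)cc1`, differs from compound 3 as follows: 4-(dimethylamino)phenyl in place of 1H-indol-3-yl on a double-bonded chain carbon bound to a double-bonded chain carbon. Going by the values given here, no measured step covers this exact exchange. Among the compounds with values here, what does bear on it is that the same group entering here is already carried by compound 1, which differs from compound 4 only elsewhere and sits at the high end of the series; the sole measured step shows the indole lowering the number. Both pointers go the same way, so the expectation is a rise, probably larger than the scatter, but compound 1 also carries a different benzyl sulfide, so its number is an upper pointer rather than a direct match.

The step is therefore expected to be a 15-fold higher number from compound 3 to compound 4 (1.18 log units; beyond the scatter). Compound 4 is estimated at 15000 nM, with a range from 4000 nM to 50000 nM in this assay.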

Compound 4, concentration for 50% growth inhibition: 50000 nM
Estimate against measurement, compound 4: 3.3-fold (0.52 log units) below; measured number inside the range.
By their numbers in this assay, from the lowest: compound 3; then compound 2; then compounds 1 and 4 (each within the scatter of the next).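

With the benzyl sulfide held constant, this position now has three measured groups in this assay: the step to 4-(dimethylamino)phenyl gives a 50-fold higher number from compound 3 to compound 4 (1.70 log units; beyond the scatter) and a 5.0-fold higher number from compound 2 to compound 4 (0.70 log units; beyond the scatter), so 1H-indol-3-yl, 2-methoxyphenyl and 4-(dimethylamino)phenyl run from the lowest number to the highest, with each gap beyond the scatter. The exchange on the saturated chain carbon bound to a sulfur gives no change at the digits printed from compound 1 to compound 4 (within the scatter), so with 4-(dimethylamino)phenyl in place, 4-fluorophenyl and 2,4-dichlorophenyl cannot be told apart, and the high number of compound 1 now reads as a fair match for this group rather than only an upper pointer. Nothing at hand accounts for the size of these differences.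

From the compounds shown here alone, whether the low number of compound 3 depends on the hydrogen on the indole nitrogen stays open, and a 1-methyl-1H-indol-3-yl or a naphthyl group at this place would test that. For the compounds shown here, also open is whether the benzyl exchange remains silent alongside 1H-indol-3-yl, since the single pair that reads it carries 4-(dimethylamino)phenyl.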